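A Second Nitro Placement on the Shared Core

This account rests on a few compounds, and the source may have more. Where it says the series, first, only, none or still open, it means among the compounds named here.

Going by the values given here, in a functional assay on A549/CDDP cells (Homo sapiens) for antiproliferative activity, read by MTT assay, with a stated time of 72 h (on this read-out lower numbers stand for stronger inhibition and higher numbers for weaker inhibition), compound 1 (`Cc1nc(C)c(/C=C/C(=O)/C=C/c2ccccc2)nc1C`) gives 11900 nM as one of only two measured numbers. In this assay compound 2 (`Cc1nc(C)c(/C=C/C(=O)/C=C/c2cccc([N+](=O)[O-])c2)nc1C`) gives 6690 nM and so lies within the scatter of compound 1, which leaves compound 1 without a clear rank.

Compound 3 (`Cc1nc(C)c(/C=C/C(=O)/C=C/c2ccc([N+](=O)[O-])cc2)nc1C`) carries a single change from compound 1 (nitro in place of hydrogen on an aromatic carbon), with nitro in place of hydrogen on an aromatic carbon, para to a large group. Among the compounds with values here, the one measured step that bears on this change is the same replacement in compound 2 (a 1.8-fold lower number from compound 1 to compound 2 (0.25 log units; within the scatter)), and that step does not rise beyond the scatter. Within the data shown here, it is also only one step, and the data hold no measurement for the placement in compound 3. A slightly lower number is therefore the most that can be read from it, and no clear shift is expected in this assay for this change. The estimated move is small (a 1.5-fold lower number from compound 1 to compound 3 (0.17 log units; within the scatter)) and is expected to stay within the scatter. Compound 3 is expected at 8000 nM (estimated range 3500 nM to 18000 nM).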

Compound 3, half-maximal inhibitory concentration: 7900 nM
For compound 3 the middle estimate is 1.0-fold (0.01 log units) above the measured one; low and high end bracket the measured number.
By their numbers in this assay, from the lowest: compounds 2, 3 and 1 (each within the scatter of the next).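

In this assay, nitro in place of hydrogen on an aromatic carbon, para to a large group, gives a 1.5-fold lower number from compound 1 to compound 3 (0.18 log units; within the scatter). This adds a second placement of the same replacement on the shared core, and at this position too the step stays within the scatter, so compound 3 cannot be told apart from compound 1 by this read-out. Compound 2 and compound 3 also lie within the scatter of each other, which means that the two nitro placements shown give no clear difference in this assay and neither placement can be ranked above the other. No supporting measurement is available to explain these small steps.

Whether an amine or a carboxylic acid, para to a large group on the same core, would move the number beyond the scatter remains open, since hydrogen and nitro are the only two groups shown at this position. As far as these compounds go, it also remains open whether a methoxy group or a halogen such as chlorine on this aromatic ring would give a step that can be read clearly.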